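Nitro for ethoxycarbonyl on an aziridine urea scaffold

A few compounds are considered here, and "the series" means these few. Any claim that something is new, unique, unknown or untested is made for them only; others in the source may bear on it.

Measured compounds:
compound 1, `CCOC(=O)c1ccc(NC(=O)N2CC2C#N)cc1`: 4200 nM
compound 2, `N#CC1CN1C(=O)Nc1cccnc1`: 18000 nM

In a functional assay on WiDr cells (Homo sapiens) for inhibition (on this read-out lower numbers stand for stronger inhibition and higher numbers for weaker inhibition), compound 1 gives 4200 nM, the lowest of the two numbers recorded. Compound 2 gives 18000 nM, a higher number that lies beyond the usual scatter, so compound 1 is the more potent of the pair on this evidence. Compound 3, `N#CC1CN1C(=O)Nc1ccc([N+](=O)[O-])cc1`, has not yet been measured in this assay. It differs from compound 1 in one place: nitro in place of ethoxycarbonyl on an aromatic carbon. Going by the values given here, the two groups exchanged on the aromatic carbon are comparable in what is counted, and no step between measured compounds informs the exchange, so the expected step is small and within the scatter, with no clear direction. Compound 3 is therefore expected to come close to compound 1, at 5000 nM, within a range of 1500 nM to 16000 nM, a step of a 1.2-fold higher number from compound 1 to compound 3 (0.08 log units; within the scatter).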

Compound 3, half-maximal inhibitory concentration: 3700 nM
For compound 3 the middle estimate is 1.4-fold (0.13 log units) above the measured one; the range from low to high includes it.
By their numbers in this assay, from the lowest: compounds 3 and 1 (each within the scatter of the next); then compound 2.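

In this assay, going by these compounds alone, nitro in place of ethoxycarbonyl on the aromatic carbon para to a group of 8 heavy atoms gives a 1.1-fold lower number from compound 1 to compound 3 (0.06 log units; within the scatter) and so no step that can be told from the scatter. This is the first one-place step among the compounds shown, and it indicates that the full ethoxycarbonyl, with its 5 heavy atoms, is not required at this position: nitro, with 3 heavy atoms and the same count of hydrogen-bond acceptors, serves equally well on this read-out. No measured property of either group is available to account for the match.

As far as these compounds go, whether this position would also accept an amine or a carboxylic acid remains open. So does the question of whether an ester with a longer chain would stay level with compound 1.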